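The source may report more compounds than this note shows. Statements on the series, on what has been measured and on what is new or still open speak of the compounds shown alone.

Compound 1 `CCCCCCCCNc1cnc(C(=O)NCc2ccccc2)cn1`: 100000 nM in an ADME assay on HEL cells (Homo sapiens) for cytotoxicity, read by microscopy, with a stated time of 6 days; a higher number here means that more compound is tolerated, a lower number that less compound is tolerated.
Compound 2 `CCCCNc1nccnc1C(=O)NCc1ccccc1`: > 100000 nM, a limit of the assay, not a number.
Compound 3 `CCCCNc1cncc(C(=O)NCc2ccccc2)n1`: > 100000 nM, a limit of the assay, not a number.

Compound 3 therefore stands at the upper edge of the values shown, where (the limit of > 100000 nM in this assay, at which 2 of the 3 values shown sit). Compound 4 `CCCCCCCNc1cncc(C(=O)NCc2ccccc2)n1` differs from compound 3 by propyl in place of hydrogen on a saturated chain carbon, four bonds along the chain from a nitrogen on an aromatic ring. Going by the values given here, no two measured compounds differ in a single place, so no measured step guides this change; compound 1, which carries the longest chain among the measured compounds, gives 100000 nM in this assay. The step of a number no higher from compound 3 to compound 4 (the limit leaves the size open) is expected to be small, if anything toward slightly less tolerance, and within the scatter. Compound 4 is expected to give 100000 nM, with a range from 50000 nM to 100000 nM.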

Compound 4, minimum cytotoxic concentration: > 100000 nM
Compound 4: no number, only a limit; the forecaster's own chance of this, stated with the estimate: 50%; the middle value lies on the limit itself.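

No step can be read from compound 3 to compound 4, since both values are limits of the assay, not numbers: the limit of > 100000 nM in this assay, at which 3 of the 4 values shown sit. From the compounds shown here alone, whether propyl in place of hydrogen changes tolerance at all in this assay stays open.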